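Compound 3 to compound 4: the 3-chlorophenyl step

A few compounds are considered here, and "the series" means these few. Any claim that something is new, unique, unknown or untested is made for them only; others in the source may bear on it.

In a functional assay on A549 cells (Homo sapiens) for antiproliferative activity, read by MTT assay, with a stated time of 72 h (a lower number here means a stronger inhibitor, a higher number a weaker inhibitor), compound 3 `COc1ccc(-c2ccc3ncn(-c4cc(OC)c(OC)c(OC)c4)c3c2)cc1F` gives 1430 nM, the lowest number in this small series. Compound 1 `CCOc1ccc(-c2ccc3ncn(-c4cc(OC)c(OC)c(OC)c4)c3c2)cc1` gives 8550 nM. Compound 2 `COc1cc(-n2cnc3ccc(-c4ccccc4Cl)cc32)cc(OC)c1OC` gives > 10000 nM, which is a limit of the assay. Compound 4 `COc1cc(-n2cnc3ccc(-c4cccc(Cl)c4)cc32)cc(OC)c1OC` carries 3-chlorophenyl in place of 3-fluoro-4-methoxyphenyl on an aromatic carbon. Among the compounds with values here, two measured steps bear on this change, since both arrive at the group now leaving: a 6.0-fold lower number from compound 1 to compound 3 (0.78 log units; beyond the scatter) and an at least 6.9-fold lower number from compound 2 to compound 3 (0.84 log units; beyond the scatter). Losing that group should therefore reverse a gain of similar size, and this assay is expected to show a higher number. The estimated change is a 3.8-fold higher number from compound 3 to compound 4 (0.59 log units; beyond the scatter). For compound 4 the expected value is 5500 nM. The estimated range runs from 2000 nM to 10000 nM.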

Compound 4, half-maximal inhibitory concentration: 7050 nM
Beside the measured number, compound 4's estimate is 1.3-fold (0.11 log units) below it, and the stated range covers the measured number.
By their numbers in this assay, from the lowest: compound 3; then compounds 4 and 1 (each within the scatter of the next). At a limit, above all of these: compound 2.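

In this assay, replacing 3-fluoro-4-methoxyphenyl with 3-chlorophenyl gives a 4.9-fold higher number from compound 3 to compound 4 (0.69 log units; beyond the scatter), so the advantage of 3-fluoro-4-methoxyphenyl now holds against a further group at this position. Putting 3-chlorophenyl in place of 4-ethoxyphenyl gives a 1.2-fold lower number from compound 1 to compound 4 (0.08 log units; within the scatter), so these two groups are not separated here. Compound 3 alone stands apart. Compound 2 sits at a limit: the limit of > 10000 nM in this assay, at which 1 of the 4 values shown sits. Putting 3-chlorophenyl in place of 2-chlorophenyl gives an at least 1.4-fold lower number from compound 2 to compound 4 (0.15 log units; that floor lies within the scatter), so this step offers only a floor and does not separate these two groups.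

The compounds shown do not separate the fluorine from the methoxy group of 3-fluoro-4-methoxyphenyl, which 3-fluorophenyl and 4-methoxyphenyl would do. On these data alone, how an aminophenyl group would read at this position also stays open.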